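Inverting One Ring Carbon of the Weakest Measured Compound

The compounds below may be only part of what the source reports. "The series", "measured", "known", "first", "only" and "open" are said of these compounds alone.

Measured so far:
Compound 1, `CCOC(=O)[C@@H]1CCC[C@H](S(=O)(=O)c2ccc(S(=O)(=O)N(CC)CC)cc2)C1`: 21500 nM
Compound 2, `CCOC(=O)[C@@H]1CCCN(S(=O)(=O)c2ccc(S(=O)(=O)N(CC)C(C)C)cc2)C1`: 1000 nM
Compound 3, `CCN(CC)S(=O)(=O)c1ccc(S(=O)(=O)N2CCC[C@@H](c3cc(C)no3)C2)cc1`: 4900 nM

All three compounds were tested in a functional assay on MIA PaCa-2 cells (Homo sapiens) for inhibition, read by MTT assay, with a stated time of 7 days; a lower number here means a stronger inhibitor, a higher number a weaker inhibitor. In this assay compound 1 gives 21500 nM, the highest number of the three and therefore the weakest inhibitor measured here; compound 3 gives 4900 nM and compound 2 gives 1000 nM, both beyond the scatter from compound 1. No two of these compounds differ in a single place, so none of them gives a measured step that could guide the next one.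

Compound 4, `CCOC(=O)[C@@H]1CCC[C@@H](S(=O)(=O)c2ccc(S(=O)(=O)N(CC)CC)cc2)C1`, is the unmeasured partner of compound 1. How it differs: the two compounds have the same atoms and bonds and differ only in configuration as drawn: 1 of 2 stereo elements differ; a stereocentre at a saturated ring carbon is drawn S in compound 1 and R in compound 4. The same atoms and bonds are present; only the drawn configuration at that one saturated ring carbon changes.

Nothing measured here shows how a flipped ring stereocentre moves the number in this assay. Such a change can leave the value untouched or shift it in either direction. With compound 1 already weak, a modest gain is expected, but without confidence.

Compound 4 is expected to give 15000 nM in this assay, with a range from 3000 nM to 60000 nM. That expectation means a step of a 1.4-fold lower number from compound 1 to compound 4 (0.16 log units; within the scatter).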

Compound 4, half-maximal inhibitory concentration: 16400 nM
Compound 4: middle estimate off by 1.1-fold (0.04 log units), on the low side; the measured number falls inside the stated range.
By their numbers in this assay, from the lowest: compound 2; then compound 3; then compounds 4 and 1 (each within the scatter of the next).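

Redrawing this saturated ring carbon from S to R gives a 1.3-fold lower number from compound 1 to compound 4 (0.12 log units; within the scatter) in this assay, and that step lies within the usual scatter of repeated measurements. The comparison is unusually clean because a single feature separates the two compounds: the fact that compounds 1 and 4 differ only in the configuration as drawn. Within the data shown here, it is the first measured step in this set, and it shows that, for this pair, the configuration at this one carbon produces no difference that the assay can distinguish from scatter, so compound 1 and compound 4 can be treated as equal here.

Among these compounds, this result covers only the one stereocentre that changes, on this one pair, so the other stereocentre remains an open question, as does the case in which both are inverted together. It also leaves open whether this carbon would remain as indifferent to configuration if a carboxylic acid or an amide stood in place of the ethyl ester.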